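The compounds below may be only part of what the source reports. "The series", "measured", "known", "first", "only" and "open" are said of these compounds alone.

Measured in a functional assay on HEK293 cells for positive allosteric modulation of metabotropic glutamate receptor 5 (Rattus norvegicus), read by fluorescence and calcium flux; a higher number here means a larger maximal response, a lower number a smaller maximal response:

compound 1 `C[C@@H](NC(=O)c1ccc(C#Cc2cc(F)cc(F)c2)cn1)C(C)(C)O` — 61.6%
compound 2 `Cc1ccccc1C#Cc1ccc(C(=O)N[C@H](C)C(C)(C)O)nc1` — 59.9%
compound 3 `Cc1ccc(C#Cc2ccc(C(=O)N[C@H](C)C(C)(C)O)nc2)cc1` — 63.1%

Compound 3 carries the highest of the three numbers, yet a number 1.5 percentage points higher from compound 1 to compound 3 (within the scatter) and a number 3.2 percentage points higher from compound 2 to compound 3 (within the scatter) both sit within the scatter, so the three compounds are not separated in this assay. The same holds for a number 1.7 percentage points lower from compound 1 to compound 2 (within the scatter).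

Compound 4 `C[C@@H](NC(=O)c1ccc(C#Cc2ccc(F)cn2)cn1)C(C)(C)O` differs from compound 3 in one place: 5-fluoropyridin-2-yl in place of 4-methylphenyl on a triple-bonded carbon. Among the measured compounds shown here, all three measured steps likewise swap the ring on the triple-bonded carbon, and each is within the scatter; none of them, however, brings in a ring with a hetero atom or a hydrogen-bond acceptor, so no measured step speaks directly to the change from compound 3 to compound 4. What they do show is that exchanging the ring at this place has so far left the maximal response essentially unchanged. The expectation for this assay is therefore no step beyond the scatter, a number 3.1 percentage points lower from compound 3 to compound 4 (within the scatter), with the range widened for the untested ring type. Compound 4 is estimated at 60%, between 45% and 75%.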

Compound 4, largest response reached (reported as efficacy), in percent of the reference or control that the assay uses: 64.6%
For compound 4 the middle estimate is 4.6 percentage points below the measured one; the measured number falls inside the stated range.
By their numbers in this assay, from the lowest: compounds 2, 1, 3 and 4 (each within the scatter of the next).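

In this assay, the triple-bonded carbon now also carries a ring with a hetero atom and a hydrogen-bond acceptor: a number 1.5 percentage points higher from compound 3 to compound 4 (within the scatter), a number 4.7 percentage points higher from compound 2 to compound 4 (within the scatter) and a number 3 percentage points higher from compound 1 to compound 4 (within the scatter). The series therefore extends from carbon-only rings to 5-fluoropyridin-2-yl at this place without any step beyond the scatter, so the flat picture no longer rests on carbon-only rings alone. Nothing available explains why the maximal response stays level across these rings.

Going by these compounds, all four compounds keep a six-membered aromatic ring at this place, so it remains open whether a saturated ring such as cyclohexyl would keep the response at this level. They also share the same amide side chain, which leaves open the outcome of exchanging its hydroxyl group for an amine.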